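The source may hold more compounds than are shown below. What is called first, only, known or untested is meant among the compounds shown, and "the series" means these compounds.

Compound 1, `CCCn1c(=O)n(C)c(=O)c2c1ncn2CC(N)=O`, and compound 2, `CCCn1c(=O)n(C)c(=O)c2c1ncn2CC#N`, share one core and differ only in the group on a saturated chain carbon bound to an aromatic nitrogen. In an assay on Cerebral cortex for binding affinity to adenosine receptor A1 (Cavia porcellus), read by radioligand binding (a lower number here means a stronger inhibitor, a higher number a weaker inhibitor), compound 1 gives > 200000 nM, which is a limit of the assay and not a number. In this assay, for the measured compounds named here, compound 2 gives 6600 nM, and this is the only number among the two values shown, the other value being (the limit of > 200000 nM in this assay, at which 1 of the 2 values shown sits). Going by the values given here, the single measured step is an at least 30-fold lower number from compound 1 to compound 2 (1.48 log units; beyond the scatter), an exchange of carbamoyl for cyano at that place.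

Compound 3, `CCCn1c(=O)n(C)c(=O)c2c1ncn2CCC#N`, carries cyanomethyl in place of cyano on a saturated chain carbon bound to an aromatic nitrogen. Among the compounds with values here, no measured step covers this lengthening of the chain by one carbon; the step of an at least 30-fold lower number from compound 1 to compound 2 (1.48 log units; beyond the scatter) exchanged one terminal group for another at the same place and does not tell how carrying the cyano group one carbon further out will read. For compound 3 a change within the scatter, or at most a modest one in either direction, is therefore expected in this assay, namely a 1.3-fold lower number from compound 2 to compound 3 (0.12 log units; within the scatter). The estimate for compound 3 is 5000 nM, with a range from 1500 nM to 20000 nM.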

Compound 3, inhibition constant: 88600 nM
Compound 3: middle estimate off by 18-fold (1.25 log units), on the low side, and the stated range ends below it.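

In this assay the place on a saturated chain carbon bound to an aromatic nitrogen proves sensitive to more than the identity of the terminal group: with the nitrile kept and only the chain lengthened, cyanomethyl in place of cyano gives a 13-fold higher number from compound 2 to compound 3 (1.13 log units; beyond the scatter). The earlier pair, with an at least 30-fold lower number from compound 1 to compound 2 (1.48 log units; beyond the scatter), had shown only that exchanging the terminal group matters, whereas this step shows that the distance of the nitrile from the shared core matters too, and that a gain from the nitrile does not carry over unchanged to the longer chain. Compound 3 still reads lower than compound 1, with an at least 2.2-fold lower number from compound 1 to compound 3 (0.35 log units; beyond the scatter), but this step is only a bound, as it rests on a limit of the assay and not on a number: the limit of > 200000 nM in this assay, at which 1 of the 3 values shown sits.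

The compounds shown leave open whether a still longer chain ending in a nitrile would raise the number further, and whether lengthening the chain would also shift the reading for a terminal carbamoyl group. They also leave open how an amine or a carboxylic acid at the end of the chain would read in this assay.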